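From fluoro to methoxy on a weak compound

The source may report more compounds than this note shows. Statements on the series, on what has been measured and on what is new or still open speak of the compounds shown alone.

Measured so far in a functional assay on P388 cells (Mus musculus) for inhibition (a higher number here means a weaker inhibitor, a lower number a stronger inhibitor), as follows:
- Compound 1 `Cc1cccc(/C=C2\CCc3ccccc3C2=O)c1` gives 16300 nM
- Compound 2 `CN(C)c1ccc(/C=C2\CCc3ccccc3C2=O)cc1` gives 5300 nM
- Compound 3 `O=C1CCCCC/C1=C\c1cccc(F)c1` gives > 50000 nM

Compound 3 has no number: its entry (> 50000 nM) is a limit of this assay. Compound 4 `COc1cccc(/C=C2\CCCCCC2=O)c1` keeps the core of compound 3 and carries methoxy in place of fluoro on an aromatic carbon. Going by the values given here, no measured pair shows this change. A small step towards stronger inhibition is expected, or none beyond the scatter. With compound 3 at its limit (> 50000 nM) the expectation stays close to that limit. The estimated step (an at least 1.1-fold lower number from compound 3 to compound 4 (0.04 log units; that floor lies within the scatter)) is expected to be small. For compound 4 the expected value is 45000 nM within an estimated range of 18000 nM to 80000 nM and a report as a limit alone is quite possible.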

Compound 4, half-maximal inhibitory concentration: 50000 nM
For compound 4 the middle estimate is 1.1-fold (0.05 log units) below the measured one, within the range that was stated.
By their numbers in this assay, from the lowest: compound 2; then compound 1; then compound 4.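

In this assay, methoxy in place of fluoro on an aromatic carbon, meta to a group of 9 heavy atoms, gives a number no higher from compound 3 to compound 4 (the limit leaves the size open). Going by these compounds alone, compound 4 gives 50000 nM, which puts a number on this position, and the earlier compounds held no pair for this change. The entry of compound 3 is a limit, and the size of the step cannot be read because of it: the limit of > 50000 nM in this assay, at which 1 of the 4 values shown sits.

Open, as far as these compounds go, is how a carboxylic acid at this place on the ring of compound 4 would read against methoxy. Also open, from the compounds shown here alone, is whether any group here gives a number clearly lower than that of compound 4.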